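A few compounds are considered here, and "the series" means these few. Any claim that something is new, unique, unknown or untested is made for them only; others in the source may bear on it.

Measured in a functional assay on SK-BR-3 cells (Homo sapiens) for cytotoxicity, read by resazurin assay, with a stated time of 72 h; on this read-out lower numbers stand for stronger inhibition and higher numbers for weaker inhibition:
Compound 1 `N#CCCSC(=S)NCc1cccnc1`: 2840 nM.
Compound 2 `O=C(CCSC(=S)NCc1cccnc1)NCc1ccccc1`: > 100000 nM, a limit of the assay rather than a number.
Compound 3 `S=C(NCc1cccnc1)SCCc1nnc(-c2ccccc2)o1`: 580 nM.

Compound 3 holds the lowest of the two numbers; the nearest number, that of compound 1, lies beyond the scatter of repeated measurements. The value of compound 2 is only a limit (the limit of > 100000 nM in this assay, at which 1 of the 3 values shown sits). Compound 4 `S=C(NCc1cccnc1)SCCc1nnc(-c2cc[nH]c2)o1` differs from compound 3 by 1H-pyrrol-3-yl in place of phenyl on an aromatic carbon; the rest of the structure is kept. Among the measured compounds shown here, no measured pair isolates this change, so the expectation rests on it being a small change at the far end of the molecule. In this assay the step of a 1.4-fold higher number from compound 3 to compound 4 (0.14 log units; within the scatter) is expected to be modest, at most a slight weakening near the scatter. Compound 4 is estimated at 800 nM, with a range from 300 nM to 2500 nM.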

Compound 4, half-maximal inhibitory concentration: 820 nM
Estimate against measurement, compound 4: 1.0-fold (0.01 log units) below; low and high end bracket the measured number.
By their numbers in this assay, from the lowest: compounds 3 and 4 (each within the scatter of the next); then compound 1. At a limit, above all of these: compound 2.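

In this assay, replacing phenyl with 1H-pyrrol-3-yl on this aromatic carbon gives a 1.4-fold higher number from compound 3 to compound 4 (0.15 log units; within the scatter), so this position accepts a five-membered aromatic ring carrying a hydrogen-bond donor as readily as the six-membered carbon ring. Among the compounds shown here, this is the first comparison that isolates a single place. The data shown give no reason for this outcome.

Going by these compounds, whether an amine or a carboxylic acid on the phenyl ring would be accepted remains open. So does the effect of a longer chain between the shared core and the five-membered ring.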